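Aryl versus methyl on the amide-bearing carbon

The source may hold more compounds than are shown below. What is called first, only, known or untested is meant among the compounds shown, and "the series" means these compounds.

Compound 1 `CC(=O)NC(c1cccs1)c1cc(Cl)c2cccnc2c1O`: 1000 nM
Compound 2 `CCC(=O)NC(C)c1cc(Cl)c2cccnc2c1O`: > 50000 nM

Of the compounds shown here, two sharing the same core have been measured in an assay for inhibition of Polyunsaturated fatty acid lipoxygenase ALOX12 (Homo sapiens), read by spectrophotometry; a higher number here means a weaker inhibitor, a lower number a stronger inhibitor. Compound 1 gives 1000 nM. For compound 2 only a limit is known, > 50000 nM, and this is a limit of the assay rather than a number (the limit of > 50000 nM in this assay, at which 1 of the 2 values shown sits). Compound 2 therefore stands at the weak end of what has been seen, with its true value unresolved.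

Compound 3 `CCC(=O)NC(c1ccc(C)cc1)c1cc(Cl)c2cccnc2c1O` has not yet been measured. It differs from compound 2 in one place: 4-methylphenyl in place of methyl on a saturated chain carbon bound to an amide-type nitrogen and an aromatic carbon. Among the compounds with values here, the only measured compound that carries a ring instead of a methyl on that carbon is compound 1, and compound 1 sits well inside the measurable range. Within the data shown here, no measured pair follows this exact change, so the size of the step must be guessed. The step from compound 2 to compound 3 is expected to be large, toward stronger inhibition, at about an at least 20-fold lower number from compound 2 to compound 3 (1.30 log units; beyond the scatter). Compound 3 is estimated at 2500 nM, within a range from 500 nM to 15000 nM.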

Compound 3, half-maximal inhibitory concentration: > 150000 nM
Compound 3 ended at the assay's limit (the forecaster's own chance of this, stated with the estimate: 15%); middle value at least 60-fold (1.77 log units) from the limit.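

Within the data shown here, compound 2 and compound 3 both stand at limits rather than at numbers, so no step between them can be read. The compounds shown leave open whether 4-methylphenyl in place of methyl on that saturated chain carbon changes inhibition at all, and how far either true value lies from its limit.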